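The compounds below may be only part of what the source reports. "The series", "measured", "known", "first", "only" and "open" are said of these compounds alone.

The series was tested in a functional assay on CRL2813 cells (Homo sapiens) for cytotoxicity, read by sulforhodamine B assay, with a stated time of 5 days; on this read-out lower numbers stand for stronger inhibition and higher numbers for weaker inhibition. Compound 1, `O=C(Nc1cccc(C(F)(F)F)c1)N[C@H]1CC[C@H](O)CC1`, reached only the limit of the assay, giving > 20000 nM in this read-out. Compound 2, `CSc1ccccc1NC(=O)N[C@H]1CC[C@H](Oc2ccc(F)cc2)CC1`, likewise returned only a limit, > 20000 nM. For the measured compounds named here, both readings sit at the limit of > 20000 nM in this assay, at which 2 of the 2 values shown sit, so nothing beyond that limit is known for either compound, and no step between measured compounds can be drawn from these two. Compound 3, `O=C(Nc1ccccc1Cl)N[C@H]1CC[C@H](Oc2ccc(F)cc2)CC1`, remains to be tested in this assay. It differs from compound 2 by chloro in place of methylsulfanyl on an aromatic carbon. With compound 2 known only as a limit in this assay, no step can be sized from the numbers shown, and there is no ground to expect a change beyond the scatter in either direction. Compound 3 is therefore expected to give about 30000 nM, with a range from 10000 nM to 100000 nM, most likely again reported as a limit. The expected step that this estimate implies is a step that the limit leaves unreadable from compound 2 to compound 3.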

Compound 3, half-maximal inhibitory concentration: 9100 nM
Beside the measured number, compound 3's estimate is 3.3-fold (0.52 log units) above it; measured number outside the range, below it.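

In this assay, the change from 2-(methylsulfanyl)phenyl to 2-chlorophenyl brings the series its first reading that is not a limit, with an at least 2.1-fold lower number from compound 2 to compound 3 (0.34 log units; beyond the scatter). This shows that the group on this aromatic carbon, ortho to a large group, can alter the read-out, which compounds 1 and 2 could not show on their own. The true size of the step remains unknown, as compound 2 is known only as a limit: the limit of > 20000 nM in this assay, at which 2 of the 3 values shown sit.

What the compounds shown leave open is how other groups at this place, such as methoxy, fluoro or an amine, would compare with chloro. A single pair also cannot tell whether the same exchange would give a similar step on a different core, or which feature of the exchange accounts for this one.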